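This account rests on a few compounds, and the source may have more. Where it says the series, first, only, none or still open, it means among the compounds named here.

Compounds measured so far in a functional assay on MV4-11 cells (Homo sapiens) for antiproliferative activity, with a stated time of 6 days, tested at 1.56 uM; on this read-out higher numbers stand for a stronger effect at the one concentration tested and lower numbers for a weaker effect:
- compound 1, `CNC(=O)N1CCCc2ccc(NC(=O)c3ccc(-c4cnn(S(C)(=O)=O)c4)cc3)cc21`, compound 1 gives 4.5%
- compound 2, `CNC(=O)N1CCCc2ccc(NC(=O)c3ccc(-c4cc[nH]n4)cc3)cc21`, compound 2 gives 92.5%
- compound 3, `CNC(=O)N1CCCc2ccc(NC(=O)c3ccc(-c4ccccn4)cc3)cc21`, compound 3 gives 32%

Compound 3 sits second highest of the three numbers; its nearest neighbour is compound 1, which is a number 27.5 percentage points higher from compound 1 to compound 3 (beyond the scatter), and its furthest is compound 2, which is a number 60.5 percentage points lower from compound 2 to compound 3 (beyond the scatter). The exchange at the same aromatic carbon between compound 1 and compound 2 was a number 88 percentage points higher from compound 1 to compound 2 (beyond the scatter).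

Compound 4 is `CNC(=O)N1CCCc2ccc(NC(=O)c3ccc(-c4cnn(C)c4)cc3)cc21`. It differs from compound 3 only in that (1-methyl-1H-pyrazol-4-yl in place of pyridin-2-yl on an aromatic carbon). Among the compounds with values here, the group that enters is not present in any measured compound, so no measured step reproduces the change exactly. The two steps that touch compound 3 (a number 27.5 percentage points higher from compound 1 to compound 3 (beyond the scatter) and a number 60.5 percentage points lower from compound 2 to compound 3 (beyond the scatter)) show that a change of the aryl group para to a large group can move the read-out across nearly the whole range in this assay. Within the data shown here, compound 1, the only other pyrazol-4-yl compound, gives 4.5%; compound 2, the only other pyrazole, gives 92.5%.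

For compound 4 the expected step is a number 8 percentage points higher from compound 3 to compound 4 (within the scatter), small and within the scatter, with a wide range because the measured steps point in both directions. The estimate for compound 4 is therefore 40%, expected between 10% and 75%.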

Compound 4, a percentage reported as inhibition, at one concentration (the size of the read-out at that concentration, not a potency): 77.4%
Compound 4: middle estimate off by 37.4 percentage points, on the low side; measured number above the stated range.
By their numbers in this assay, from the lowest: compound 1; then compound 3; then compound 4; then compound 2.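

In this assay the 1-methyl-1H-pyrazol-4-yl group places a pyrazol-4-yl compound high in the range, so this ring attachment does not by itself keep the read-out low: methyl in place of methylsulfonyl on the aromatic nitrogen gives a number 72.9 percentage points higher from compound 1 to compound 4 (beyond the scatter), and the group on that nitrogen separates these two compounds. At the aromatic carbon para to a large group, the exchange from pyridin-2-yl gives a number 45.4 percentage points higher from compound 3 to compound 4 (beyond the scatter), while the exchange from 1H-pyrazol-3-yl gives the smaller a number 15.1 percentage points lower from compound 2 to compound 4 (beyond the scatter); both pyrazoles with a methyl or a hydrogen on nitrogen therefore stand above the pyridine, with compound 1 going against any wider claim for five-membered rings. No evidence on the cause of these differences is available.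

Open, from the compounds shown here alone, is how the read-out responds to other groups on that nitrogen, such as ethyl, acetyl or 2-hydroxyethyl, and to the unsubstituted 1H-pyrazol-4-yl, which would compare directly with both the methyl and the 1H-pyrazol-3-yl groups. Also open, going by these compounds, is whether pyridin-3-yl or pyridin-4-yl would stay near compound 3 or rise towards the pyrazoles.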